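Methylsulfanyl for methyl at the ethynyl-bearing core

The source may report more compounds than this note shows. Statements on the series, on what has been measured and on what is new or still open speak of the compounds shown alone.

Compound 3 `C#Cc1cn([C@@H]2O[C@H](CO)[C@@H](O)[C@H]2O)c2ncnc(C)c12` gives the lowest number of the three measured, 50 nM in an ADME assay on BJ cells (Homo sapiens), read by MTT assay, with a stated time of 72 h; a higher number here means a weaker inhibitor, a lower number a stronger inhibitor. Compound 1 `C#Cc1cn([C@@H]2O[C@H](CO)[C@@H](O)[C@H]2O)c2ncnc(N(C)C)c12` gives 410 nM, and compound 2 `CSc1ncnc2c1c(-c1cccs1)cn2[C@@H]1O[C@H](CO)[C@@H](O)[C@H]1O` gives 96900 nM. Within the data shown here, the one step that touches this position of the core is an 8.2-fold lower number from compound 1 to compound 3 (0.91 log units; beyond the scatter). Compound 4 `C#Cc1cn([C@@H]2O[C@H](CO)[C@@H](O)[C@H]2O)c2ncnc(SC)c12` differs from compound 3 by methylsulfanyl in place of methyl on an aromatic carbon. Among the measured compounds shown here, no measured step covers this exact exchange; compound 2 also carries methylsulfanyl, but its other substituent differs, so its value alone shows only that methylsulfanyl is compatible with a very high number. Given that compound 1 shows 410 nM after a change at the same carbon, a weakening step of an 8.0-fold higher number from compound 3 to compound 4 (0.90 log units; beyond the scatter) is expected, with wide uncertainty. Compound 4 is estimated at 400 nM, within 80 nM to 3000 nM.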

Compound 4, half-maximal inhibitory concentration: 68600 nM
For compound 4 the middle estimate is 170-fold (2.23 log units) below the measured one; measured number outside the range, above it.
By their numbers in this assay, from the lowest: compound 3; then compound 1; then compounds 4 and 2 (each within the scatter of the next).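

With ethynyl held constant, methylsulfanyl at this aromatic carbon gives a far higher number than either methyl (a 1400-fold higher number from compound 3 to compound 4 (3.14 log units; beyond the scatter)) or dimethylamino (a 170-fold higher number from compound 1 to compound 4 (2.22 log units; beyond the scatter)). With methylsulfanyl held constant, exchanging thiophen-2-yl for ethynyl stays within the scatter (a 1.4-fold lower number from compound 2 to compound 4 (0.15 log units; within the scatter)), so the high number of compound 2 does not depend on thiophen-2-yl. No measurement available here explains the jump. Still open, going by these compounds, is where methoxy, ethylsulfanyl or a primary amine would fall at this carbon. Also open, on these data alone, is whether methyl keeps its low number alongside thiophen-2-yl.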